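This account rests on a few compounds, and the source may have more. Where it says the series, first, only, none or still open, it means among the compounds named here.

Among the compounds with values here, compound 1 `CCCCNC(=O)C1CCN(c2nc(N)c3cc(OC)c(OC)cc3n2)CC1` gives 0.67 nM in an assay on isolated protein for displacement of a labelled ligand from Adrenergic receptor alpha-1 (Rattus norvegicus) (on this read-out higher numbers stand for weaker inhibition and lower numbers for stronger inhibition), the lowest number among the three measured members. Compound 3 `CCCCNC(=O)CC1CCN(c2nc(N)c3cc(OC)c(OC)cc3n2)CC1` gives 1.4 nM in this assay, and compound 2 `COc1cc2nc(N3CCC(C(=O)NCCO)CC3)nc(N)c2cc1OC` gives 1.73 nM. Both neighbours sit higher: the step of a 2.1-fold higher number from compound 1 to compound 3 (0.32 log units; beyond the scatter) and the step of a 2.6-fold higher number from compound 1 to compound 2 (0.41 log units; beyond the scatter) are each beyond the scatter, while the step of a 1.2-fold lower number from compound 2 to compound 3 (0.09 log units; within the scatter) is not.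

Compound 4 `COc1cc2nc(N3CCC(CC(=O)NCC4CC4)CC3)nc(N)c2cc1OC` has not been measured in this assay. It differs from compound 1 by ((cyclopropylmethyl)carbamoyl)methyl in place of butylcarbamoyl on a saturated ring carbon. Part of this change, the (butylcarbamoyl)methyl in place of butylcarbamoyl, is exactly what separates compound 1 from compound 3, and that step a 2.1-fold higher number from compound 1 to compound 3 (0.32 log units; beyond the scatter) is the one that bears directly. Within the data shown here, the remaining part, a cyclopropylmethyl end in place of the butyl end on the amide, has no measured pair of its own; the step of a 1.2-fold lower number from compound 2 to compound 3 (0.09 log units; within the scatter), which changes the amide end together with the chain, stays within the scatter, so little further movement is assumed from it. A modest step toward a higher number is therefore expected for compound 4, close to the size seen from compound 1 to compound 3. Compound 4 is estimated at 1.5 nM in this assay, with a range of 0.7 nM to 3.5 nM. The expected step is a 2.2-fold higher number from compound 1 to compound 4 (0.35 log units; beyond the scatter).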

Compound 4, inhibition constant: 1.08 nM
Estimate against measurement, compound 4: 1.4-fold (0.14 log units) above, within the range that was stated.
By their numbers in this assay, from the lowest: compounds 1, 4, 3 and 2 (each within the scatter of the next, the first and the last beyond it).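

In this assay the step of a 1.6-fold higher number from compound 1 to compound 4 (0.21 log units; within the scatter) stays within the scatter, whereas the step to (butylcarbamoyl)methyl in compound 3 lay beyond it, so this saturated ring carbon, three ring bonds from the ring nitrogen, carries ((cyclopropylmethyl)carbamoyl)methyl with no change that can be read. Cyclopropyl in place of propyl gives a 1.3-fold lower number from compound 3 to compound 4 (0.11 log units; within the scatter) and so cannot be told apart from the open chain end. The new group is likewise not separated from (2-hydroxyethyl)carbamoyl, with a 1.6-fold lower number from compound 2 to compound 4 (0.20 log units; within the scatter) as the step, so the amide ends shown here have moved the number little.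

Open, as far as these compounds go, is whether a carboxylic acid or an amine at the amide end, or a longer chain between the ring carbon and the carbonyl, would stay in this narrow band. Nothing at hand accounts for the small differences among these compounds.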